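Three triazole thioethers at the assay limit; a fourth awaited

This account rests on a few compounds, and the source may have more. Where it says the series, first, only, none or still open, it means among the compounds named here.

Compound 1 `Cc1nnc(SCC(=O)c2ccccc2)n1N1C(=O)c2ccccc2C1=O`: in a functional assay on A549 cells (Homo sapiens) for cytotoxicity, read by MTT assay, with a stated time of 48 h (a higher number here means a weaker inhibitor, a lower number a stronger inhibitor), compound 1 gives > 200000 nM, a limit.
Compound 2 `C#CCSc1nnc(C)n1N1C(=O)c2ccccc2C1=O`: in this assay compound 2 gives > 200000 nM, a limit.
Compound 3 `CSc1nnc(C)n1N1C(=O)c2ccccc2C1=O`: in this assay compound 3 gives > 200000 nM, a limit.

Compound 3 stands at the limit of > 200000 nM in this assay, at which 3 of the 3 values shown sit; no number separates it from the others. The steps a step that the two limits leave unreadable from compound 1 to compound 3, a step that the two limits leave unreadable from compound 2 to compound 3 and a step that the two limits leave unreadable from compound 1 to compound 2 are all unreadable, since both ends sit at the limit. Compound 4 `Cc1nnc(SCc2ccccc2Cl)n1N1C(=O)c2ccccc2C1=O` differs from compound 3 by 2-chlorophenyl in place of hydrogen on a saturated chain carbon bound to a sulfur. For the measured compounds named here, no measured step on that chain carbon gave a readable size, so there is no basis to expect compound 4 to leave the limit in this assay. The step is therefore expected to be about a step that the limit leaves unreadable from compound 3 to compound 4, within the scatter. Compound 4 is expected to give about 250000 nM, in a range from 60000 nM to 1000000 nM.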

Compound 4, half-maximal inhibitory concentration: > 200000 nM
Compound 4: only a limit was reported; the forecaster's own chance of this, stated with the estimate: 80%; the middle value does not contradict the limit.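

Compound 4 sits at the same limit as compound 1, compound 2 and compound 3, so no step among them can be read: the limit of > 200000 nM in this assay, at which 4 of the 4 values shown sit.

The compounds shown leave open whether any group on that chain carbon gives a measurable value in this assay.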